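Chloro in Place of Fluoro: Estimating Compound 3

This account rests on a few compounds, and the source may have more. Where it says the series, first, only, none or still open, it means among the compounds named here.

Compound 1 `O=C(CSc1nc(Nc2ccccc2)c2ccccc2n1)Nc1ccccc1Cl` gives 9610 nM in a functional assay on NCI-H1975 cells (Homo sapiens) for inhibition, read by MTT assay, with a stated time of 72 h; a higher number here means a weaker inhibitor, a lower number a stronger inhibitor.
Compound 2 `O=C(CSc1nc(Nc2ccccc2)c2ccccc2n1)Nc1cccc(F)c1` gives 6790 nM in this assay.

Compound 2 holds the lower of the two numbers, but the gap between them is a 1.4-fold lower number from compound 1 to compound 2 (0.15 log units; within the scatter), so the two compounds cannot be told apart on the data shown. Compound 3 `O=C(CSc1nc(Nc2ccccc2)c2ccccc2n1)Nc1cccc(Cl)c1` differs from compound 2 by chloro in place of fluoro on an aromatic carbon. Among the measured compounds shown here, no measured step exchanges one halogen for another at the same place; the single step from compound 1 to compound 2 changes both the halogen and its place on the ring, and it stayed within the scatter. The data therefore give no reason to expect more than a small shift in this assay, in either direction, for compound 3. Compound 3 is estimated at 5000 nM, with a range of 2000 nM to 15000 nM. The expected step from compound 2 to compound 3 is a 1.4-fold lower number from compound 2 to compound 3 (0.13 log units; within the scatter).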

Compound 3, half-maximal inhibitory concentration: 8460 nM
Estimate against measurement, compound 3: 1.7-fold (0.23 log units) below; the range from low to high includes it.
By their numbers in this assay, from the lowest: compounds 2, 3 and 1 (each within the scatter of the next).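

With compound 3, the exchange of one halogen for another at a single place can be read on its own: in this assay, 3-chlorophenyl in place of 3-fluorophenyl gives a 1.2-fold higher number from compound 2 to compound 3 (0.10 log units; within the scatter) and leaves the compounds indistinguishable. The place of the chloro can now also be read separately from the identity of the halogen, and a 1.1-fold lower number from compound 1 to compound 3 (0.06 log units; within the scatter) likewise leaves the two compounds indistinguishable. No evidence bearing on these small steps is available.

As far as these compounds go, all three compounds carry a single halogen on this phenyl ring, so it remains open whether a group of another kind there, such as a methoxy group, an amine or a carboxylic acid, would move the number beyond the scatter. From the compounds shown here alone, the effect of a longer chain in place of the link to the amide also remains open.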